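The source may hold more compounds than are shown below. What is called first, only, known or untested is meant among the compounds shown, and "the series" means these compounds.

Compound 1 `COc1cc(-c2nn(-c3cccc(NC(=O)c4ccc(Cl)c(C(F)(F)F)c4)c3)cc2-c2ccncc2)ccc1Cl` carries an amide at the position of interest. In a functional assay on NCI-H322M cells (Homo sapiens) for inhibition, read by sulforhodamine B assay, with a stated time of 48 h (on this read-out higher numbers stand for weaker inhibition of growth and lower numbers for stronger inhibition of growth), compound 1 gives only a limit, > 32500 nM, and this is the limit of > 32500 nM in this assay, at which 1 of the 3 values shown sits. Compound 3 `COc1cc(-c2nn(-c3cccc(NC(=O)Nc4cccc(C(F)(F)F)c4)c3)cc2-c2ccncc2)ccc1Cl` gives 4730 nM in this assay, and compound 2 `O=C(Nc1cccc(-n2cc(-c3ccncc3)c(-c3ccc(Cl)c(O)c3)n2)c1)Nc1cc(C(F)(F)F)cc(C(F)(F)F)c1` gives 5390 nM. Compound 4 `COc1cc(-c2nn(-c3cccc(NC(=O)Nc4ccc(Cl)c(C(F)(F)F)c4)c3)cc2-c2ccncc2)ccc1Cl` has not yet been measured; it differs from compound 1 in one place: (4-chloro-3-(trifluoromethyl)phenyl)amino in place of 4-chloro-3-(trifluoromethyl)phenyl on a carbonyl carbon. Among the measured compounds shown here, one measured step bears on this change, an at least 6.8-fold lower number from compound 1 to compound 3 (0.83 log units; beyond the scatter), in which the amide also becomes a urea, and compound 2 shows a second urea at a similar level. A lower number by a comparable margin is therefore expected, an at least 8.1-fold lower number from compound 1 to compound 4 (0.90 log units; beyond the scatter). Compound 4 is estimated to give 4000 nM in this assay, within a range from 1500 nM to 12000 nM.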

Compound 4, concentration for total growth inhibition: 13900 nM
Estimate against measurement, compound 4: 3.5-fold (0.54 log units) below, outside the stated range (above it).
By their numbers in this assay, from the lowest: compounds 3 and 2 (each within the scatter of the next); then compound 4. At a limit, above all of these: compound 1.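

In this assay, the urea still gives a lower number than the amide when the chloro group is present, with an at least 2.3-fold lower number from compound 1 to compound 4 (0.36 log units; beyond the scatter). The chloro group, however, carries a cost in this urea pair, with a 2.9-fold higher number from compound 3 to compound 4 (0.47 log units; beyond the scatter). The full size of the amide-to-urea step cannot be stated because the amide compound 1 gives only a limit: the limit of > 32500 nM in this assay, at which 1 of the 4 values shown sits.

The compounds shown leave open whether a fluoro, methoxy or amine group in place of that chloro would lower the number. They also leave open whether the cost of the chloro group would recur in an amide pair.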